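The source may hold more compounds than are shown below. What is called first, only, known or untested is meant among the compounds shown, and "the series" means these compounds.

Measured compounds:
- compound 1 `CS(=O)(=O)c1ccc(C(=O)N2CCC(C(=O)N3CCc4ccccc4C3)CC2)cc1[N+](=O)[O-]`: in an assay on isolated protein for inhibition of thyroid hormone receptor beta (Homo sapiens), read by fluorescence polarization (a higher number here means a weaker inhibitor, a lower number a stronger inhibitor), compound 1 gives > 60000 nM, which is a limit of the assay and not a number.
- compound 2 `CS(=O)(=O)c1ccc(C(=O)NCCC(=O)N2CCc3ccccc32)cc1[N+](=O)[O-]`: in this assay compound 2 gives > 60000 nM, again a limit.
- compound 3 `CN(CC(=O)N1CCN(c2ccc(C(F)(F)F)cc2)CC1)C(=O)c1ccc(S(C)(=O)=O)c([N+](=O)[O-])c1`: in this assay compound 3 gives > 60000 nM, also a limit.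

Going by the values given here, compound 1 therefore stands at the limit of > 60000 nM in this assay, at which 3 of the 3 values shown sit; no compound of the series has yet given a number, so no step between measured compounds can be sized and no ordering among them is possible.

Compound 4 `CC(C)N(C(=O)C1CCN(C(=O)c2ccc(S(C)(=O)=O)c([N+](=O)[O-])c2)CC1)C(C)C` differs from compound 1 in one place: diisopropylamino in place of 1,2,3,4-tetrahydroisoquinolin-2-yl on a carbonyl carbon. The shared core of compound 1 is kept unchanged, as it is in compound 2 and compound 3.

Among the compounds with values here, with no measured step to draw on, the expectation for the step that the limit leaves unreadable from compound 1 to compound 4 is that it stays within the scatter, in no particular direction. The estimate for compound 4 in this assay is 100000 nM, with a range from 30000 nM to 300000 nM, most likely reported once more as a limit rather than as a number.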

Compound 4, half-maximal inhibitory concentration: > 60000 nM
Compound 4: a limit, no number (the forecaster's own chance of this, stated with the estimate: 85%); the middle value does not contradict the limit.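

Going by these compounds alone, no step can be read between compound 1 and compound 4, as both values are limits and not numbers, like every value in this assay so far: the limit of > 60000 nM in this assay, at which 4 of the 4 values shown sit.

The compounds shown leave open which change to the shared core of compound 1, if any, would give a number in this assay.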